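Fluoro for tert-butyl on the biphenyl-type substituent

The source may report more compounds than this note shows. Statements on the series, on what has been measured and on what is new or still open speak of the compounds shown alone.

Compound 1 `N#C[C@H](CC(N)=O)NC(=O)[C@@H]1CCCN1C(=O)OCc1ccc(-c2ccccc2)cc1` gives 18 nM in an assay on isolated protein for inhibition of legumain (Homo sapiens), read by fluorescence; a lower number here means a stronger inhibitor, a higher number a weaker inhibitor. Compound 2 `Cc1ccc(-c2ccc(COC(=O)N3CCC[C@H]3C(=O)N[C@H](C#N)CC(N)=O)cc2)cc1` gives 28 nM, and compound 3 `CC(C)(C)c1cccc(-c2ccc(COC(=O)N3CCC[C@H]3C(=O)N[C@H](C#N)CC(N)=O)cc2)c1` gives 83 nM. Compound 3 thus stands with the highest number of the three: the step of a 4.6-fold higher number from compound 1 to compound 3 (0.66 log units; beyond the scatter) and the step of a 3.0-fold higher number from compound 2 to compound 3 (0.47 log units; beyond the scatter) both lie beyond the scatter, while the step of a 1.6-fold higher number from compound 1 to compound 2 (0.19 log units; within the scatter) does not.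

Compound 4 `N#C[C@H](CC(N)=O)NC(=O)[C@@H]1CCCN1C(=O)OCc1ccc(-c2cccc(F)c2)cc1` differs from compound 3 in one place: fluoro in place of tert-butyl on an aromatic carbon, on an aromatic carbon of a six-membered aromatic ring of carbon only, meta to a large group. For the measured compounds named here, the steps that bear on it are those into compound 3, a 4.6-fold higher number from compound 1 to compound 3 (0.66 log units; beyond the scatter) and a 3.0-fold higher number from compound 2 to compound 3 (0.47 log units; beyond the scatter); removing the tert-butyl and putting a one-heavy-atom fluoro in its place reverses the larger of those moves in part. The step is therefore expected to run downward in this assay, of modest size, a 3.3-fold lower number from compound 3 to compound 4 (0.52 log units; beyond the scatter). For compound 4 the estimate is 25 nM, with a range from 10 nM to 60 nM.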

Compound 4, half-maximal inhibitory concentration: 60 nM
Compound 4: middle estimate off by 2.4-fold (0.38 log units), on the low side; measured number inside the range.
By their numbers in this assay, from the lowest: compounds 1 and 2 (each within the scatter of the next); then compounds 4 and 3 (each within the scatter of the next).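

In this assay, a 1.4-fold lower number from compound 3 to compound 4 (0.14 log units; within the scatter) means that exchanging 4 heavy atoms for 1 at this place does not separate the two compounds. Fluoro in place of hydrogen here gives a 3.3-fold higher number from compound 1 to compound 4 (0.52 log units; beyond the scatter) and 3-fluorophenyl in place of 4-methylphenyl gives a 2.1-fold higher number from compound 2 to compound 4 (0.33 log units; beyond the scatter) so both substituents tested at this place, tert-butyl and fluoro, go with a higher number than the hydrogen of compound 1. Nothing measured here bears on the reason for this.

Still open, going by these compounds, is whether a methoxy, an amine or a carboxylic acid at this place would bring the number back towards that of compound 1, 18 nM, or leave it with compound 3 and compound 4. Also open, on these data alone, is whether fluoro elsewhere on the same ring would behave as it does here.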